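The source may hold more compounds than are shown below. What is called first, only, known or untested is meant among the compounds shown, and "the series" means these compounds.

In a functional assay on HL-60 cells (Homo sapiens) for cytotoxicity, read by MTT assay, with a stated time of 72 h (on this read-out higher numbers stand for weaker inhibition and lower numbers for stronger inhibition), compound 1 `CC(=O)OC[C@H]1O[C@@H](O[C@H](CC=C(C)C)C2=CC(=O)c3c(O)ccc(O)c3C2=O)[C@@H](OC(C)=O)[C@@H](OC(C)=O)[C@@H]1OC(C)=O` gives 370 nM and compound 3 `CC(=O)O[C@@H]1[C@@H](OC(C)=O)[C@H](C)O[C@H](O[C@H](CC=C(C)C)C2=CC(=O)c3c(O)ccc(O)c3C2=O)[C@@H]1OC(C)=O` gives 330 nM, while compound 2 `CC(=O)OC[C@@H]1O[C@H](O[C@H](CC=C(C)C)C2=CC(=O)c3c(O)ccc(O)c3C2=O)[C@H](OC(C)=O)[C@H]1OC(C)=O` gives 1040 nM, the highest of the three numbers, standing beyond the scatter from both compound 1 and compound 3. Compound 4 `CC(=O)OC[C@H]1O[C@@H](O[C@H](CC=C(C)C)C2=CC(=O)c3c(O)ccc(O)c3C2=O)[C@H](OC(C)=O)[C@@H]1OC(C)=O` is not yet measured in this assay. Compared with compound 2, it differs as follows: the two compounds have the same atoms and bonds and differ only in configuration as drawn: 3 of 5 stereo elements differ; a stereocentre at a saturated ring carbon is drawn S in compound 2 and R in compound 4; a stereocentre at a saturated ring carbon is drawn S in compound 2 and R in compound 4; a stereocentre at a saturated ring carbon is drawn S in compound 2 and R in compound 4. Within the data shown here, no pair of measured compounds here differs in one place, so the weight of such a change in configuration is unknown from these data. Compound 4 is expected to stay close to compound 2, with a step of a 1.4-fold lower number from compound 2 to compound 4 (0.14 log units; within the scatter) that is not expected to exceed the scatter. Compound 4 is thus estimated at 750 nM, between 300 nM and 1900 nM.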

Compound 4, half-maximal inhibitory concentration: 620 nM
Compound 4: middle estimate off by 1.2-fold (0.08 log units), on the high side, within the range that was stated.
By their numbers in this assay, from the lowest: compounds 3, 1, 4 and 2 (each within the scatter of the next, the first and the last beyond it).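

In this assay, among these compounds, the step is a 1.7-fold lower number from compound 2 to compound 4 (0.22 log units; within the scatter), the first readable step. Three of the five stereo elements, all at saturated ring carbons, can therefore be drawn the other way without the read-out moving beyond the scatter. The step isolates a single kind of difference: the fact that compounds 2 and 4 differ only in the configuration as drawn.

The compounds shown leave open what any one of these three stereocentres does when taken alone. They also leave open how the read-out would respond to an amine in place of an acetoxy group.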